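Pyridin-2-yl for 4-methoxyphenyl on a carbonyl carbon

The source may hold more compounds than are shown below. What is called first, only, known or untested is meant among the compounds shown, and "the series" means these compounds.

Measured so far in a functional assay on MDA-MB-231 cells (Homo sapiens) for antiproliferative activity, with a stated time of 4 days; on this read-out lower numbers stand for stronger inhibition and higher numbers for weaker inhibition:
compound 1 `CCCCc1ccc2[nH]c(-c3ccc(C(F)(F)F)cc3)c(C=O)c2c1` (33 nM)
compound 2 `CCCCc1ccc2[nH]c(-c3ccc(OC)cc3)c(/C=N/NC(=O)c3ccc(OC)cc3)c2c1` (61 nM)
compound 3 `CCCCc1ccc2[nH]c(-c3ccc(CC)cc3)c(/C=N/NC(=O)c3cccnc3)c2c1` (53 nM)

Compound 2 (61 nM) stands level with the other two: its number lies within the usual scatter of both compound 3 and compound 1, so these data do not rank it against either. The next compound, compound 4 `CCCCc1ccc2[nH]c(-c3ccc(OC)cc3)c(/C=N/NC(=O)c3ccccn3)c2c1`, changes one place of compound 2 (pyridin-2-yl in place of 4-methoxyphenyl on a carbonyl carbon), with pyridin-2-yl in place of 4-methoxyphenyl on a carbonyl carbon. Going by the values given here, no two measured compounds differ in just one place, so nothing here shows directly what this swap does in this assay. The closest hint is compound 3 (53 nM), which also holds a ring with a hetero atom on that carbonyl carbon, although it differs from compound 2 elsewhere too, and its number falls within the scatter of compound 2. The expected step (a 1.1-fold lower number from compound 2 to compound 4 (0.04 log units; within the scatter)) is therefore none beyond the scatter, with no clear direction. Compound 4 is expected to read 55 nM in this assay (estimated range 22 nM to 140 nM).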

Compound 4, half-maximal inhibitory concentration: 34 nM
The estimate for compound 4 lay 1.6-fold (0.21 log units) above the measured number; measured number inside the range.
By their numbers in this assay, from the lowest: compounds 1, 4, 3 and 2 (each within the scatter of the next).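

Going by these compounds alone, this is the first direct comparison at this position: in this assay, replacing 4-methoxyphenyl with pyridin-2-yl on the carbonyl carbon gives a 1.8-fold lower number from compound 2 to compound 4 (0.25 log units; within the scatter). The two compounds therefore cannot be ranked, and this position can carry a ring with a nitrogen atom and fewer heavy atoms without a change that stands out from repeat-measurement noise. Nothing measured here offers an explanation for the size of this step.

The compounds shown do not reveal whether a plain phenyl ring or a saturated ring such as piperidine on this carbonyl carbon would also stay within the scatter, or whether a carboxylic acid on the ring would shift the number clearly. They also leave open whether the same swap would give a similar step with different groups elsewhere on the shared core.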